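The compounds below may be only part of what the source reports. "The series", "measured", "known", "first", "only" and "open" are said of these compounds alone.

Measured so far:
compound 1 `Cc1c(C(=O)Nc2ccc(Oc3ccnc4[nH]ccc34)c(F)c2)nnn1-c1ccc(F)c(Cl)c1` — 730 nM
compound 2 `O=C(Nc1ccc(Oc2ccnc3[nH]ccc23)c(F)c1)c1nnn(-c2ccccc2)c1C(F)(F)F` — 220 nM
compound 3 `O=C(Nc1ccc(Oc2ccnc3[nH]ccc23)c(F)c1)c1nnn(-c2ccc(F)c(F)c2)c1C(F)(F)F` — 350 nM

All three were tested in a functional assay on A549 cells (Homo sapiens) for cytotoxicity, read by MTT assay, with a stated time of 72 h; a higher number here means a weaker inhibitor, a lower number a stronger inhibitor. Compound 3 gives 350 nM, the second highest of the three numbers; it sits within the usual scatter of compound 2 and apart from compound 1, whose number lies beyond the scatter above it. Compound 4 `O=C(Nc1ccc(Oc2ccnc3[nH]ccc23)c(F)c1)c1nnn(-c2ccc(F)c(Cl)c2)c1C(F)(F)F` differs from compound 3 in one place: chloro in place of fluoro on an aromatic carbon. Among the measured compounds shown here, the only measured step of a comparable kind is the change from compound 2 to compound 3, where a 3,4-difluorophenyl replaced a phenyl on an aromatic nitrogen, and that gave a 1.6-fold higher number from compound 2 to compound 3 (0.20 log units; within the scatter). A swap of one halogen for another on the same ring is a smaller change than that, so compound 4 is expected to stay close to compound 3 in this assay, with at most a modest rise in the number, a 1.3-fold higher number from compound 3 to compound 4 (0.11 log units; within the scatter). Compound 4 is therefore estimated at 450 nM, within a range from 200 nM to 1000 nM.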

Compound 4, half-maximal inhibitory concentration: 820 nM
Beside the measured number, compound 4's estimate is 1.8-fold (0.26 log units) below it; low and high end bracket the measured number.
By their numbers in this assay, from the lowest: compounds 2 and 3 (each within the scatter of the next); then compounds 1 and 4 (each within the scatter of the next).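

In this assay, among the compounds shown here, the halogen at this ring carbon counts for more than the earlier compounds suggested: chloro in place of fluoro gives a 2.3-fold higher number from compound 3 to compound 4 (0.37 log units; beyond the scatter) and so moves the number beyond the scatter. Replacing the plain phenyl with 3-chloro-4-fluorophenyl gives a 3.7-fold higher number from compound 2 to compound 4 (0.57 log units; beyond the scatter) in the same direction, whereas 3,4-difluorophenyl gave only a 1.6-fold higher number from compound 2 to compound 3 (0.20 log units; within the scatter) within the scatter. With the 3-chloro-4-fluorophenyl held constant, trifluoromethyl in place of methyl gives a 1.1-fold higher number from compound 1 to compound 4 (0.05 log units; within the scatter) and stays within the scatter, so this pair shows no clear difference between those two groups.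

No measurement shown here accounts for the effect of the chloro group. Going by these compounds, it remains open how a bromo, methyl or methoxy group at this ring carbon would compare.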